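This account rests on a few compounds, and the source may have more. Where it says the series, first, only, none or still open, it means among the compounds named here.

Compound 1 `O=Cc1ccc(-c2cn3ccnc3c(-c3ccc4ncn(C5CCCCC5)c4c3)n2)cc1` gives 77.9% in a functional assay on CCRF-CEM cells (Homo sapiens) for inhibition, read by sulforhodamine B assay, with a stated time of 48 h, tested at 10 uM; on this read-out lower numbers stand for less inhibition and higher numbers for more inhibition at the one concentration tested (going by the name of the read-out).
Compound 2 `Fc1ccc(-c2cn3ccnc3c(-c3ccc4ncn(C5CCCCC5)c4c3)n2)cc1` gives 33.4% in this assay.

For the measured compounds named here, compound 2 stands at the lowest of the two numbers measured so far. Going by the values given here, its only neighbour is compound 1, and the single step between them, a number 44.5 percentage points lower from compound 1 to compound 2 (beyond the scatter), shows that changing the group on the outer ring can move the read-out a long way.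

Compound 3 `c1csc(-c2cn3ccnc3c(-c3ccc4ncn(C5CCCCC5)c4c3)n2)c1` has not yet been measured in this assay. It differs from compound 2 in one place: thiophen-2-yl in place of 4-fluorophenyl on an aromatic carbon. Among the compounds with values here, no measured step exchanges this whole ring; the one step seen, a number 44.5 percentage points lower from compound 1 to compound 2 (beyond the scatter), only swaps a group on the ring that now leaves, so it bears on the new change indirectly, as a sign that this part of the molecule matters for the read-out. Without a direct precedent, a step in either direction is possible; a moderate rise from the lowest number seems the likelier outcome, and the expected step is a number 8.6 percentage points higher from compound 2 to compound 3 (within the scatter). Compound 3 is therefore estimated at 42%, with a range from 20% to 66%.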

Compound 3, a percentage reported as inhibition, at one concentration (the size of the read-out at that concentration, not a potency): 46.4%
Beside the measured number, compound 3's estimate is 4.4 percentage points below it; the range from low to high includes it.
By their numbers in this assay, from the lowest: compound 2; then compound 3; then compound 1.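

Exchanging the whole ring at this position, rather than only a group on it, still leaves a measurable read-out in this assay: thiophen-2-yl in place of 4-fluorophenyl gives a number 13 percentage points higher from compound 2 to compound 3 (beyond the scatter), so a five-membered aromatic ring with a sulfur atom serves here at least as well as the fluorinated six-membered ring. Against the ring carrying the formyl group, the same thiophen-2-yl gives a number 31.5 percentage points lower from compound 1 to compound 3 (beyond the scatter), which leaves compound 1 clearly on top of the three and places compound 3 between the other two, much nearer to compound 2 by its printed value. Nothing available here explains why these three groups rank in this order.

On these data alone, what remains open is whether the high number of compound 1 belongs to the formyl group itself or would also appear with another group on the same phenyl ring, such as a carboxylic acid, a nitrile or an amine. It is also unclear whether a formyl group carried on the thiophen-2-yl ring would raise compound 3 in the same way, or whether a furan-2-yl ring would behave like thiophen-2-yl.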